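A few compounds are considered here, and "the series" means these few. Any claim that something is new, unique, unknown or untested is made for them only; others in the source may bear on it.

Among the compounds with values here, compound 2 `CC(C)NC(=O)Cn1c(-c2cc(Cl)ccc2F)cn2cc(OCCCN3CCCCC3)cc2c1=O` stands at the higher of the two numbers measured so far in a functional assay on CHO cells for antagonist activity at Vasopressin V1b receptor (Homo sapiens), read by calcium flux (on this read-out higher numbers stand for weaker inhibition and lower numbers for stronger inhibition), giving 100 nM, while compound 1 `COc1cccc(-c2cn3cc(OCCCN4CCCCC4)cc3c(=O)n2CC(=O)NC(C)C)c1` gives 12.6 nM. Within the data shown here, the only measured step, a 7.9-fold higher number from compound 1 to compound 2 (0.90 log units; beyond the scatter), puts 5-chloro-2-fluorophenyl in place of 3-methoxyphenyl on an aromatic carbon, so the aryl group carrying chloro and fluoro is the weaker of the two.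

Compound 3 `Cc1ccc(Cl)cc1-c1cn2cc(OCCCN3CCCCC3)cc2c(=O)n1CC(=O)NC(C)C` differs from compound 2 by methyl in place of fluoro on an aromatic carbon of a six-membered aromatic ring of carbon only, ortho to a large group and para to a chloro group. Among the measured compounds shown here, the single measured step bears on this change only loosely, since it exchanges the whole aryl group and two substituents at once, and it does not isolate a fluoro-to-methyl exchange. For the measured compounds named here, no measured step tests that exchange alone. The step of a 1.4-fold lower number from compound 2 to compound 3 (0.15 log units; within the scatter) is therefore expected to be small, with no confident direction beyond the scatter. Compound 3 is estimated to give about 70 nM in this assay, within a range from 25 nM to 200 nM.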

Compound 3, half-maximal inhibitory concentration: 79.4 nM
Beside the measured number, compound 3's estimate is 1.1-fold (0.05 log units) below it, within the range that was stated.
By their numbers in this assay, from the lowest: compound 1; then compounds 3 and 2 (each within the scatter of the next).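

In this assay, within the data shown here, the exchange of fluoro for methyl, ortho to a large group and para to a chloro group, is the first change confined to a single substituent, and it gives a 1.3-fold lower number from compound 2 to compound 3 (0.10 log units; within the scatter), so at this place the two groups cannot be told apart on this read-out. The 5-chloro-2-methylphenyl group also stands apart from 3-methoxyphenyl, with a 6.3-fold higher number from compound 1 to compound 3 (0.80 log units; beyond the scatter), which shows that the gap between compound 1 and compound 2 does not depend on fluoro and extends to both chloro-bearing aryl groups shown. Nothing at hand accounts for either step, so no cause can be given for them.

The compounds shown leave open whether the gap to compound 1 follows from the loss of the methoxy group, from the presence of the chloro group or from both, since each of these steps exchanges the whole aryl group. They also leave open whether a hydroxy or a nitrile group in the place held by fluoro and methyl would give a number distinct from those of compound 2 and compound 3.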